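A Small Swap, Measured Once and Expected Again

The source may report more compounds than this note shows. Statements on the series, on what has been measured and on what is new or still open speak of the compounds shown alone.

Four compounds share a common core and differ in one small group attached to an aromatic ring. Compound 1, `C/C=C/C(=O)N(Cc1ccc(OC)c(OC)c1)c1cc(OC)c(OC)c(OC)c1`, was tested in a functional assay on HCT-116 cells (Homo sapiens) for inhibition, read by MTT assay, with a stated time of 48 h (a lower number here means a stronger inhibitor, a higher number a weaker inhibitor), and in this assay compound 1 gives 32800 nM. Compound 2, `C/C=C/C(=O)N(Cc1ccc(OC)c(C)c1)c1cc(OC)c(OC)c(OC)c1`, differs from compound 1 only by methyl in place of methoxy on an aromatic carbon. In this assay compound 2 gives 23500 nM. The step of a 1.4-fold lower number from compound 1 to compound 2 (0.14 log units; within the scatter) shows that this exchange changed the result hardly at all.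

Compound 3, `COc1ccc(CNc2cc(OC)c(OC)c(OC)c2)cc1`, gives 18400 nM in this assay. Compound 3 and compound 1 are built on cores that differ in several respects at once, and the difference between the two cores is not broken down here. The three measured values all lie close to one another, so none of them can be singled out.

Compound 4, `COc1cc(NCc2ccc(C)cc2)cc(OC)c1OC`, has not yet been measured. Compound 4 differs from compound 3 by methyl in place of methoxy on an aromatic carbon. Going by the values given here, this is the same kind of change as the one from compound 1 to compound 2, but not the same change: in compound 1 the exchanged group sits ortho to a methoxy group (2 heavy atoms) and meta to a large group, whereas in compound 3 it sits para to a large group.

For compound 4 a step of a 1.2-fold lower number from compound 3 to compound 4 (0.06 log units; within the scatter) is expected, because a 1.4-fold lower number from compound 1 to compound 2 (0.14 log units; within the scatter) shows the same kind of exchange left the value essentially unchanged. The estimate for compound 4 in this assay is 16000 nM, expected to fall between 7000 nM and 36000 nM.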

Compound 4, half-maximal inhibitory concentration: > 80000 nM
Compound 4 ended at the assay's limit; the forecaster's own chance of this, stated with the estimate: 5%; middle value at least 5.0-fold (0.69 log units) from the limit.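

In this assay compound 4 gives > 80000 nM, which is a limit of the assay and not a number. On this core, methyl in place of methoxy on an aromatic carbon gives an at least 4.3-fold higher number from compound 3 to compound 4 (0.63 log units; beyond the scatter), so a swap that made no clear difference on the core of compound 1 does not carry over unchanged to the core of compound 3: the same change on two cores in this assay, a 1.4-fold lower number (0.14 log units; within the scatter) from compound 1 to compound 2 and an at least 4.3-fold higher number (0.63 log units; beyond the scatter) from compound 3 to compound 4, at least 6.0-fold (0.78 log units) apart, beyond the scatter of two such steps This shows that the earlier step cannot be relied on to predict this exchange on the other core, but it does not show why the two results part, as the cores differ in several respects and the comparison rests on just two pairs, and the limit also leaves the full size of the new step unknown.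

Still open, going by these compounds, is how other groups in the same place, para to a large group, would behave on the core of compound 3, for example a fluorine atom, a hydroxyl group or an ethyl group, and whether any of them would stay as close to compound 3 as methoxy and methyl do not. Also open, on these data alone, is whether the same gap between the two cores would appear in any other cell line.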